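Returning a methoxy group at a new position

The compounds below may be only part of what the source reports. "The series", "measured", "known", "first", "only" and "open" are said of these compounds alone.

Within the data shown here, in a functional assay on SF-295 cells (Homo sapiens) for inhibition, read by sulforhodamine B assay, with a stated time of 48 h, tested at 10 uM (a higher number here means more inhibition at the concentration tested (going by the name of the read-out), a lower number less inhibition), compound 2 `O=Cc1ccc(-c2cn3ccnc3c(-c3ccc4ncn(C5CCCCC5)c4c3)n2)cc1` gives 23.1%, the lower of the two numbers known, while compound 1 `COc1ccc(-c2cn3ccnc3c(-c3ccc4ncn(C5CCCCC5)c4c3)n2)cc1` gives 92.5%. Compound 3 `COc1ccccc1-c1cn2ccnc2c(-c2ccc3ncn(C4CCCCC4)c3c2)n1` carries 2-methoxyphenyl in place of 4-formylphenyl on an aromatic carbon. Among the measured compounds shown here, the one measured step that bears on this change is a number 69.4 percentage points lower from compound 1 to compound 2 (beyond the scatter), and compound 3 undoes that exchange, although its methoxy group does not sit where it sits in compound 1. A large rise is therefore expected, with some allowance for the changed position. The estimated value for compound 3 is 75%, expected between 45% and 95%, a step of a number 51.9 percentage points higher from compound 2 to compound 3 (beyond the scatter).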

Compound 3, a percentage reported as inhibition, at one concentration (the size of the read-out at that concentration, not a potency): 9.76%
The estimate for compound 3 lay 65.2 percentage points above the measured number; measured number outside the range, below it.
By their numbers in this assay, from the lowest: compound 3; then compound 2; then compound 1.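

In this assay, the methoxy group does not restore the number on its own: 2-methoxyphenyl in place of 4-methoxyphenyl gives a number 82.7 percentage points lower from compound 1 to compound 3 (beyond the scatter), and 2-methoxyphenyl in place of 4-formylphenyl gives a number 13.3 percentage points lower from compound 2 to compound 3 (beyond the scatter). Among these three compounds, then, only the 4-methoxyphenyl group of compound 1 goes with high inhibition, and where the methoxy group sits on the phenyl ring matters at least as much as its presence. No measurement at hand explains this loss. From the compounds shown here alone, whether an amine or a hydroxyl group on the phenyl ring could match methoxy in compound 1 remains open.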